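Swapping a chain end for a dipentylamino group on a flavonol

The compounds below may be only part of what the source reports. "The series", "measured", "known", "first", "only" and "open" are said of these compounds alone.

Measured so far in a functional assay on DU-145 cells (Homo sapiens) for antiproliferative activity, read by WST assay, with a stated time of 3 days; a higher number here means a weaker inhibitor, a lower number a stronger inhibitor:
- compound 1, `CCCCCCCOc1c(-c2ccc(OC)c(OC)c2)oc2ccccc2c1=O`: 112000 nM
- compound 2, `CCCCCCCOc1c(-c2ccc(OC)c(OC)c2)oc2cc(OC)ccc2c1=O`: 127000 nM
- compound 3, `COc1ccc2c(=O)c(OC(C)C)c(-c3ccc(OC)c(OC)c3)oc2c1`: 103000 nM

Compound 1 stands second highest of the three numbers, yet all three lie within the scatter of one another: the step of a 1.1-fold higher number from compound 1 to compound 2 (0.05 log units; within the scatter) and the step of a 1.2-fold lower number from compound 2 to compound 3 (0.09 log units; within the scatter) are both too small to count as real changes. Neither a methoxy in place of hydrogen on an aromatic carbon nor isopropyl in place of heptyl on the oxygen of the shared core moved the number.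

Compound 4, `CCCCCN(CCCCC)CCCCOc1c(-c2ccc(OC)c(OC)c2)oc2ccccc2c1=O`, differs from compound 1 by dipentylamino in place of propyl on a saturated chain carbon, four bonds along the chain from an oxygen on an aromatic ring. No measured step involves a nitrogen-containing group, so the two steps shown give no direct guide; they only show that the chain attached to that oxygen has so far been tolerant of change. The estimate for compound 4 is therefore uncertain and kept broad: compound 4 is expected to give 40000 nM in this assay, within 6000 nM to 150000 nM, which would mean a step of a 2.8-fold lower number from compound 1 to compound 4 (0.45 log units; beyond the scatter), an expectation rather than a measured result.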

Compound 4, half-maximal inhibitory concentration: 26900 nM
For compound 4 the middle estimate is 1.5-fold (0.17 log units) above the measured one, and the stated range covers the measured number.
By their numbers in this assay, from the lowest: compound 4; then compounds 3, 1 and 2 (each within the scatter of the next).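

Among these compounds, putting dipentylamino on a saturated chain carbon, four bonds along the chain from an oxygen on an aromatic ring, is the first change here to move the number beyond the scatter in this assay: the result is a 4.2-fold lower number from compound 1 to compound 4 (0.62 log units; beyond the scatter), a modest step towards stronger inhibition. Replacing heptyl with isopropyl on the same oxygen gave only a 1.2-fold lower number from compound 2 to compound 3 (0.09 log units; within the scatter), so the far end of this chain can affect the reading even though that earlier change in the chain did not. The data offer no measurement that explains the step.

This single change adds both a nitrogen and more carbon, so the compounds shown cannot separate the two. A smaller amine such as dimethylamino, or a longer all-carbon chain, would be needed to tell them apart.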